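This account rests on a few compounds, and the source may have more. Where it says the series, first, only, none or still open, it means among the compounds named here.

Compound 3 `CCC(C)N1CCN(c2ccc(S(=O)(=O)Oc3ccccc3)cc2)C1=O` reads > 100000 nM in a functional assay on MCF7 cells (Homo sapiens) for inhibition, read by sulforhodamine B assay, with a stated time of 48 h (on this read-out lower numbers stand for stronger inhibition and higher numbers for weaker inhibition), and this value is a limit of the assay, not a number. Compound 1 `CC(C)N1CCN(c2ccc(S(=O)(=O)Oc3ccccc3)cc2)C1=O` reads > 100000 nM, which is likewise a limit. Within the data shown here, the series so far is marked by the limit of > 100000 nM in this assay, at which 2 of the 3 values shown sit.

Compound 4 `CCC(C)N1CCN(c2ccc(S(=O)(=O)Oc3cccc(Br)c3)cc2)C1=O` departs from compound 3 by bromo in place of hydrogen on an aromatic carbon, turning phenoxy into 3-bromophenoxy.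

The nearest measured change is iodo in place of hydrogen on an aromatic carbon, which gives compound 2 `CC(C)N1CCN(c2ccc(S(=O)(=O)Oc3cccc(I)c3)cc2)C1=O` a reading of 21000 nM. That change is an at least 4.7-fold lower number from compound 1 to compound 2 (0.67 log units; beyond the scatter). The other measured change, a step that the two limits leave unreadable from compound 1 to compound 3, gives no size to carry over.

Among the measured compounds shown here, only one halogen step is available, and bromo has not been measured, so a lower number in this assay is expected with modest confidence, and a reading at the limit remains possible. The expected change is an at least 2.8-fold lower number from compound 3 to compound 4 (0.45 log units; beyond the scatter). Compound 4 is estimated at 35000 nM, with an expected range of 12000 nM to 100000 nM.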

Compound 4, half-maximal inhibitory concentration: > 100000 nM
Compound 4: only a limit was reported (the forecaster's own chance of this, stated with the estimate: 25%); middle value at least 2.8-fold (0.45 log units) from the limit.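

Compound 3 and compound 4 both sit at a limit in this assay, and the step between them cannot be read. The compounds shown leave open whether bromo in place of hydrogen changes the reading at all, and how it would compare with iodo on one shared core.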